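The source may report more compounds than this note shows. Statements on the series, on what has been measured and on what is new or still open speak of the compounds shown alone.

Three compounds of the series have been run in an assay for positive allosteric modulation of metabotropic glutamate receptor 3 (Rattus norvegicus); on this read-out lower numbers stand for an effect already at smaller amounts and higher numbers for an effect only at larger amounts of compound. Compound 1 `COc1ccc(C(=O)O)cc1OC[C@@H](C)COc1ccc(C(=O)CC(C)(C)C)c(O)c1C` gives 1040 nM, compound 2 `COc1ccc(C(=O)O)cc1OC[C@H](C)COc1ccc(C(=O)CC(C)(C)C)c(O)c1C` gives 384 nM, and compound 3 `Cc1c(OC[C@@H](C)COc2cc(C(=O)O)ccc2F)ccc(C(=O)CC(C)(C)C)c1O` gives 3950 nM. Compound 2 thus stands lowest of the three, with compound 1 nearest and compound 3 furthest. The step of a 2.7-fold lower number from compound 1 to compound 2 (0.43 log units; beyond the scatter) rests on configuration alone, as the fact that compounds 1 and 2 differ only in the configuration as drawn shows. The step of a 10-fold higher number from compound 2 to compound 3 (1.01 log units; beyond the scatter) follows the exchange of fluoro for methoxy on an aromatic carbon.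

Compound 4 `COc1ccc(C(=O)N(C)C)cc1OC[C@H](C)COc1ccc(C(=O)CC(C)(C)C)c(O)c1C` has not yet been measured. Its difference from compound 2 is dimethylamino in place of hydroxy on a carbonyl carbon. For the measured compounds named here, neither measured step touches this part of the molecule: one concerns configuration at the saturated chain carbon, the other the substituent on the aromatic ring, so no measured step bears directly on the carboxy to dimethylcarbamoyl change. The carboxy group of compound 2 is kept in compound 1 and compound 3 alike, so the series gives no guide to its replacement. The expected step is a 2.6-fold higher number from compound 2 to compound 4 (0.42 log units; beyond the scatter) in this assay, an upward move beyond the scatter but held with wide uncertainty. Compound 4 is estimated at 1000 nM, expected to fall between 250 nM and 4000 nM.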

Compound 4, half-maximal effective concentration: "not active" (no number reported)
Compound 4: no number reported; there is nothing to compare the estimate with.
By their numbers in this assay, from the lowest: compound 2; then compound 1; then compound 3.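

For the compounds shown here, compound 4 is reported as "not active" in this assay without a number, so no step from compound 2 to compound 4 can be read. How far the carboxy to dimethylcarbamoyl change moves the read-out stays open, as does what other groups on that carbonyl carbon would give, and nothing shown bears on this result.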